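Ethyl on the carboxymethyl chain of compound 3

The source may report more compounds than this note shows. Statements on the series, on what has been measured and on what is new or still open speak of the compounds shown alone.

Of the compounds shown here, three have been read so far in an ADME assay on the whole organism (Mus musculus, strain CD1) for pharmacokinetics, read by LC-MS, with a stated time of 24 h, at a dose of 1 mg/kg by the intravenous route (a higher number here means that more of the compound sits outside the plasma, a lower number that more of the compound stays in the plasma), and no two of them differ in one place only. Compound 1 (`O=C(O)Cn1nc(Cc2nc3cc(F)c(OCC4CC4)cc3[nH]2)c2ccccc2c1=O`) shows 28 L/kg and compound 2 (`O=C(O)Cn1nc(Cn2cc3cc(OCC4CC4)c(Cl)cc3n2)c2ccccc2c1=O`) shows 69 L/kg on this read-out. Compound 3 (`O=C(O)Cc1nn(Cc2cn3cc(OCC4CC4)c(Cl)cc3n2)c2ccccc2c1=O`) shows 18 L/kg and so stands within the scatter of compound 1. Compound 2 lies beyond the scatter from compound 3, on the higher side.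

Compound 4 (`CCC(C(=O)O)c1nn(Cc2cn3cc(OCC4CC4)c(Cl)cc3n2)c2ccccc2c1=O`) keeps the core of compound 3 and differs from it in one place (ethyl in place of hydrogen on a saturated chain carbon bound to an aromatic carbon and a carbonyl carbon), with carboxymethyl becoming 1-carboxypropyl. The new group sits on a saturated chain carbon bound to an aromatic carbon and a carbonyl carbon. Within the data shown here, no measured pair shows this change on its own, so its size cannot be read directly from the data.

The starting point is therefore compound 3 at 18 L/kg and no step beyond the scatter is expected in this assay, in either direction. The expected change is a 1.2-fold higher number from compound 3 to compound 4 (0.07 log units; within the scatter) and it is small against the spread of the three measured compounds. The range stays wide to allow for the missing precedent. Compound 4 is estimated at 21 L/kg (expected range 9 L/kg to 48 L/kg).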

Compound 4, volume of distribution at steady state: 60 L/kg
Estimate against measurement, compound 4: 2.9-fold (0.46 log units) below; measured number above the stated range.
By their numbers in this assay, from the lowest: compounds 3 and 1 (each within the scatter of the next); then compounds 4 and 2 (each within the scatter of the next).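

In this assay, among these compounds, ethyl in place of hydrogen on a saturated chain carbon bound to an aromatic carbon and a carbonyl carbon gives a 3.3-fold higher number from compound 3 to compound 4 (0.52 log units; beyond the scatter), and this is the first step that can be read at a single place. The position therefore matters on this read-out: carboxymethyl to 1-carboxypropyl, an addition of 2 heavy atoms with no ring and no net charge, is enough to carry the number beyond the scatter, towards more of the compound outside the plasma. No available measurement bears on the reason for this step.

On these data alone, whether the step is particular to ethyl stays open, since methyl, a longer chain such as propyl or a cyclopropyl ring at this place would show whether the number follows the group added or any substitution there. Also open, as far as these compounds go, is whether ethyl at this place gives a step of similar size on the core of compound 1 or of compound 2, where the acid chain is carried differently.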